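Acetyl to carboxy on a weakly active hydrazone scaffold

The source may hold more compounds than are shown below. What is called first, only, known or untested is meant among the compounds shown, and "the series" means these compounds.

Compound 3, `CC(=O)c1cccc(N/N=C2\CCC(C)n3c2ncc(C(=O)O)c3=O)c1`, carries an acetyl on the aryl hydrazone arm of the shared core. In a functional assay on the whole organism for inhibition, with Rattus norvegicus as the target (on this read-out higher numbers stand for an effect only at larger amounts of compound and lower numbers for an effect already at smaller amounts), compound 3 reaches only a limit, > 1000 umol/kg, and not a number. Its two neighbours share the core and differ only in the aryl substituent. Compound 1, `CC1CC/C(=N\Nc2cccc(Cl)c2)c2ncc(C(=O)O)c(=O)n21`, also stops at a limit in this assay, giving > 100 umol/kg. Compound 2, `CC1CC/C(=N\Nc2cccc(I)c2)c2ncc(C(=O)O)c(=O)n21`, is the only one of the three with a number in this assay, 1000 umol/kg. The steps among them cannot be sized: a step that the limit leaves unreadable from compound 1 to compound 2, a step that the two limits leave unreadable from compound 1 to compound 3 and a number no lower from compound 2 to compound 3 (the limit leaves the size open), because the limit of > 100 umol/kg in this assay, at which 1 of the 3 values shown sits, and the limit of > 1000 umol/kg in this assay, at which 1 of the 3 values shown sits, leave the sizes open. Compound 4, `CC1CC/C(=N\Nc2cccc(C(=O)O)c2)c2ncc(C(=O)O)c(=O)n21`, differs from compound 3 by hydroxy in place of methyl on a carbonyl carbon. Among the compounds with values here, no measured step exchanges an acetyl for a carboxy, so none bears directly on this change, and the three measured values offer no readable step of any kind. A step of a number no higher from compound 3 to compound 4 (the limit leaves the size open) is expected. Compound 4 is therefore estimated at 1000 umol/kg in this assay, between 300 umol/kg and 3000 umol/kg, and most likely reported again as a limit.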

Compound 4, dose for 50% inhibition: > 100 umol/kg
Compound 4 gave a limit, no number; the forecaster's own chance of this, stated with the estimate: 70%; the middle value does not contradict the limit.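

None of the steps from compound 1, compound 2 or compound 3 to compound 4 can be read in this assay, and so the result adds no new comparison. The compounds shown leave open the size and direction of any effect of changing acetyl to carboxy.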